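Methoxy Replaces Hydrogen on the Phenyl Ring of Compound 1

The compounds below may be only part of what the source reports. "The series", "measured", "known", "first", "only" and "open" are said of these compounds alone.

Compound 1 `CSc1nc(NCCCCNc2ccnc3cc(Cl)ccc23)c(C#N)c(-c2ccccc2)n1` was tested in an ADME assay on MDCK cells (Canis lupus familiaris) for cytotoxicity, read by microscopy (on this read-out lower numbers stand for higher toxicity in this test and higher numbers for lower toxicity in this test), and gave 20000 nM. This is the highest of the two numbers recorded so far in this assay; the nearest is compound 2 `CSc1nc(OCCCNc2ccnc3cc(Cl)ccc23)c(C#N)c(-c2ccccc2)n1`, which in this assay gives 4000 nM, a value that lies beyond the usual scatter. Compound 3 `COc1ccc(-c2nc(SC)nc(NCCCCNc3ccnc4cc(Cl)ccc34)c2C#N)cc1` has not yet been measured in this assay. It differs from compound 1 by methoxy in place of hydrogen on an aromatic carbon. Among the compounds with values here, no measured pair in this set shows the effect of this change, so nothing in the numbers at hand points to a step of any size, and the step expected from compound 1 to compound 3 in this assay is no change at the digits printed from compound 1 to compound 3 (within the scatter), which is within the scatter. Compound 3 is therefore expected to give about 20000 nM in this assay, with a range from 8000 nM to 50000 nM.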

Compound 3, minimum cytotoxic concentration: 20000 nM
Beside the measured number, compound 3's estimate shows no gap at the digits printed, and the stated range covers the measured number.
By their numbers in this assay, from the lowest: compound 2; then compounds 1 and 3 (each within the scatter of the next).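

Within the data shown here, the change from phenyl to 4-methoxyphenyl gives no change at the digits printed from compound 1 to compound 3 (within the scatter) in this assay and is the first reading of a substituent at this place, since compounds 1 and 2 both carry the plain phenyl and could say nothing about it. It shows that, in this one pair, methoxy on an aromatic carbon of this ring, para to a large group, leaves the read-out within the scatter. No measured information bears on why the read-out behaves this way.

Going by these compounds, it remains open how other groups at this place would read, for example an amine, a carboxylic acid or a longer chain such as butoxy. Also open, on these data alone, is whether methoxy on another aromatic carbon of the same ring, or on the ether-linked chain of compound 2, would give a similar step.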